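The source may report more compounds than this note shows. Statements on the series, on what has been measured and on what is new or still open speak of the compounds shown alone.

Of the compounds shown here, three that share a core have been measured in an in vitro ADME assay on microsomes from liver (Mus musculus) for pharmacokinetics, read by LC-MS, with a stated time of 10 min, tested at 1 uM; a higher number here means faster removal of the compound, a lower number slower removal. Compound 1 (`CN1C[C@H](C(=O)Nc2ccc(F)cc2)[C@@H](c2ccc(/C=C/C(=O)Nc3ccccc3N)cc2)C1`) gives 34 mL/min/kg, compound 2 (`Cc1ccc(NC(=O)[C@H]2CN(C)C[C@@H]2c2ccc(/C=C/C(=O)Nc3ccccc3N)cc2)cc1`) gives 62 mL/min/kg, and compound 3 (`Nc1ccccc1NC(=O)/C=C/c1ccc([C@H]2CN(C3COC3)C[C@@H]2C(=O)Nc2ccc(Cl)cc2)cc1`) gives 42 mL/min/kg. Compound 3 therefore sits within the usual scatter of both other compounds, so these numbers do not separate the three.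

The next compound to be measured is compound 4 (`Nc1ccccc1NC(=O)/C=C/c1ccc([C@H]2CN(Cc3ccccc3)C[C@@H]2C(=O)Nc2ccc(Cl)cc2)cc1`). It keeps everything in compound 3 except one group, with benzyl in place of oxetan-3-yl on an amine nitrogen in a ring.

Among the measured compounds shown here, only one measured step links two compounds that differ in a single place, a 1.8-fold higher number from compound 1 to compound 2 (0.26 log units; within the scatter). That step swaps methyl for fluoro on an aromatic carbon, so it concerns a different group at a different place, and it stays within the scatter. For the measured compounds named here, no measured step changes the group on the ring nitrogen, so the data give no direct size for this change. What remains is a judgement: a small step towards faster removal, with a real chance of no visible change. The estimated step is a 1.4-fold higher number from compound 3 to compound 4 (0.14 log units; within the scatter), which would not clearly stand beyond the scatter. For compound 4 the expected clearance is 58 mL/min/kg, with an estimated range from 32 mL/min/kg to 105 mL/min/kg.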

Compound 4, clearance: 81 mL/min/kg
Estimate against measurement, compound 4: 1.4-fold (0.15 log units) below; the range from low to high includes it.
By their numbers in this assay, from the lowest: compounds 1, 3, 2 and 4 (each within the scatter of the next, the first and the last beyond it).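

In this assay, among the compounds shown here, the change from oxetan-3-yl to benzyl on the amine nitrogen in the ring is a 1.9-fold higher number from compound 3 to compound 4 (0.29 log units; within the scatter) and is the first measured step at this position. The swap is a large one on paper, from a four-membered non-aromatic ring with 1 hetero atom and 4 heavy atoms to a six-membered aromatic ring of carbon only with 7 heavy atoms, yet the two numbers stay within the usual scatter of each other, so this pair does not show that the group on this nitrogen matters for this read-out. Nothing measured here gives a property of either group that could account for the size of this step.

Open, going by these compounds, is whether a different kind of group on this nitrogen, such as a short chain ending in a carboxylic acid or a longer plain carbon chain, would carry the number beyond the scatter. Also open is whether the step keeps its size with another group in place of the (4-chlorophenyl)carbamoyl group, the only partner with which this change is shown.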